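Replacing an Aromatic Ring with Cyclohexyl

This account rests on a few compounds, and the source may have more. Where it says the series, first, only, none or still open, it means among the compounds named here.

Compound 1 (`N#Cc1ccc(CCCCCCCCC(=O)N2CCCCC2)cc1`), compound 2 (`O=C(CCCCCCCCc1ccc(O)cc1)N1CCCCC1`) and compound 3 (`O=C(CCCCCCCCc1ccccc1Cl)N1CCCCC1`) differ only in the aromatic group on the chain. In a functional assay on PANC-1 cells (Homo sapiens) for cytotoxicity, read by WST assay, with a stated time of 24 h (a lower number here means a stronger inhibitor, a higher number a weaker inhibitor), compound 1 gives > 100000 nM as a limit and not a number. In this assay compound 2 gives > 100000 nM as a limit as well. In this assay compound 3 gives > 100000 nM as a limit too, so its position is not known as a number.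

Compound 4 (`O=C(CCCCCCCCC1CCCCC1)N1CCCCC1`) has not been measured. It carries cyclohexyl in place of 2-chlorophenyl on a saturated chain carbon, eight bonds along the chain from a carbonyl carbon.

The nearest measured changes are a step that the two limits leave unreadable from compound 1 to compound 3 and a step that the two limits leave unreadable from compound 2 to compound 3, and neither has a readable size. The series offers only the limit of > 100000 nM in this assay, at which 3 of the 3 values shown sit, as evidence. With no measured shift to carry over, the expectation is a step that the limit leaves unreadable from compound 3 to compound 4 and no change beyond the scatter in either direction. Compound 4 will most likely be reported only as a limit again. For compound 4 the estimated value is 120000 nM with an expected range from 50000 nM to 300000 nM.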

Compound 4, half-maximal inhibitory concentration: > 100000 nM
Compound 4 gave a limit, no number (the forecaster's own chance of this, stated with the estimate: 80%); the middle value lies beyond the limit too.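

Compound 4, like compound 1, compound 2 and compound 3, gives only a limit and not a number in this assay, so no step among these compounds can be read: the limit of > 100000 nM in this assay, at which 4 of the 4 values shown sit. The compounds shown leave open how strongly, if at all, any of them acts on these cells, and how they rank against one another.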